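Adding a Chloro Group to the Benzoyl Ring of Compound 3

This account rests on a few compounds, and the source may have more. Where it says the series, first, only, none or still open, it means among the compounds named here.

In a functional assay on ACHN cells (Homo sapiens) for cytotoxicity, read by sulforhodamine B assay, with a stated time of 72 h (a lower number here means a stronger inhibitor of growth, a higher number a weaker inhibitor of growth), compound 3 `O=C(Nc1ccccc1O)C1CCc2ccccc2N1C(=O)c1ccccc1` gives 4260 nM, the second highest of three numbers. Compound 1 `O=C(Nc1ccccc1C(F)(F)F)C1CCc2ccccc2N1C(=O)c1ccccc1` gives 8090 nM, and the step of a 1.9-fold lower number from compound 1 to compound 3 (0.28 log units; within the scatter) stays within the scatter. Within the data shown here, compound 2 `O=C(Nc1cc(C(F)(F)F)cc(C(F)(F)F)c1)C1CCc2ccccc2N1C(=O)c1cccc(Cl)c1` gives 813 nM, a lower number beyond the scatter, but compound 2 differs from compound 3 in two places at once, so no single measured step isolates the change considered here. Compound 4 `O=C(Nc1ccccc1O)C1CCc2ccccc2N1C(=O)c1cccc(Cl)c1` differs from compound 3 by chloro in place of hydrogen on an aromatic carbon. Among the measured compounds shown here, the only measured step concerns a different change and says nothing about this one. The expected step in this assay is therefore modest and uncertain in direction, leaning lower because the chloro-bearing compound 2 gives 813 nM. Compound 4 is estimated at 2500 nM, expected to lie between 900 nM and 7000 nM. This estimate means an expected step of a 1.7-fold lower number from compound 3 to compound 4 (0.23 log units; within the scatter).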

Compound 4, concentration for 50% growth inhibition: 17200 nM
Estimate against measurement, compound 4: 6.9-fold (0.84 log units) below; the whole stated range lies below it.
By their numbers in this assay, from the lowest: compound 2; then compounds 3 and 1 (each within the scatter of the next); then compound 4.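

In this assay, the change from benzoyl to (3-chlorophenyl)carbonyl gives a 4.0-fold higher number from compound 3 to compound 4 (0.61 log units; beyond the scatter) and so weakens growth inhibition. Among these compounds, this is the first single-change step at this position, and it shows that with the rest of compound 3 held fixed, chloro here raises the number rather than lowering it. Nothing measured on these compounds accounts for the step. The compounds shown leave open whether chloro also raises the number when trifluoromethyl replaces hydroxy on the other aromatic ring, and whether fluoro or an amine at this same place would move the number the same way.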